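Ethyl ester in place of the free acid on compound 1

The source may report more compounds than this note shows. Statements on the series, on what has been measured and on what is new or still open speak of the compounds shown alone.

Compound 1 `CC(C)(C)C(=O)OCO[P@@]1(=O)OCC(C)(C)[C@H](C(=O)NCCC(=O)O)O1` is known in an ADME assay on blood (Homo sapiens) for pharmacokinetics (a lower number here means that the compound disappears faster, a higher number that the compound lasts longer), only as a limit, > 1 h. The two other values recorded are limits as well, so compound 1 cannot be ranked against them. Compound 2 `COC(=O)CCNC(=O)[C@@H]1O[P@](=O)(OCOC(=O)c2scnc2C)OCC1(C)C` gives < 0.16 h, a limit. Compound 3 `COC(=O)CCNC(=O)[C@@H]1O[P@](=O)(OCOC(=O)c2cc(C)nn2C)OCC1(C)C` likewise gives < 0.16 h, a limit. Among the compounds with values here, the single measured step, a step that the two limits leave unreadable from compound 2 to compound 3, concerns another part of the molecule and has no bearing on the change at hand. Compound 4 `CCOC(=O)CCNC(=O)[C@@H]1O[P@@](=O)(OCOC(=O)C(C)(C)C)OCC1(C)C` differs from compound 1 by ethyl in place of hydrogen on an oxygen next to a carbonyl group. Within the data shown here, no measured step addresses this change, yet compound 2 and compound 3 both carry an ester and both sit at the limit of < 0.16 h in this assay, at which 2 of the 3 values shown sit. A downward step is therefore expected, an at least 5.0-fold lower number from compound 1 to compound 4 (0.69 log units; beyond the scatter). Compound 4 is estimated at 0.2 h, between 0.05 h and 0.8 h.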

Compound 4, half-life: 0.28 h
Estimate against measurement, compound 4: 1.4-fold (0.15 log units) below; low and high end bracket the measured number.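

In this assay, within the data shown here, ethyl in place of hydrogen on an oxygen next to a carbonyl group gives an at least 3.5-fold lower number from compound 1 to compound 4 (0.55 log units; beyond the scatter), the first readable step at this position. Turning carboxy into ethoxycarbonyl thus shortens the half-life by more than the usual scatter. The true size of the step stays unknown because compound 1 stands only at a limit: the limit of > 1 h in this assay, at which 1 of the 4 values shown sits.

On these data alone, how an isopropyl ester, a longer chain such as butyl, or a primary amide at this position would behave remains open. The compounds shown also do not tell why the half-life falls with this change.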